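From fluoro to methoxy on compound 2

The source may hold more compounds than are shown below. What is called first, only, known or untested is meant among the compounds shown, and "the series" means these compounds.

Measured in a functional assay on LoVo cells (Homo sapiens) for inhibition, read by MTT assay, with a stated time of 24 h; a higher number here means a weaker inhibitor, a lower number a stronger inhibitor:
compound 1 `CC1(C)[C@H]2CC[C@]1(C)N(Cc1cn(-c3ccc(C#N)cc3)nn1)C(=O)C2` gives 90 nM
compound 2 `CC1(C)[C@H]2CC[C@]1(C)N(Cc1cn(-c3ccccc3F)nn1)C(=O)C2` gives 40 nM

Of these two, compound 2 has the lower number, 40 nM, which makes it the stronger inhibitor. Compound 3 `COc1ccccc1-n1cc(CN2C(=O)C[C@@H]3CC[C@@]2(C)C3(C)C)nn1` carries methoxy in place of fluoro on an aromatic carbon, ortho to a large group (methoxy in place of fluoro on an aromatic carbon). Within the data shown here, the only measured step, a 2.3-fold lower number from compound 1 to compound 2 (0.35 log units; beyond the scatter), was modest and exchanged different groups, so it is only a rough guide. A similarly small change is therefore expected in this assay, leaning slightly upward, though the direction is uncertain. The expected step is a 1.4-fold higher number from compound 2 to compound 3 (0.14 log units; within the scatter). Compound 3 is estimated at 55 nM, with an expected range from 20 nM to 150 nM.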

Compound 3, half-maximal inhibitory concentration: 70 nM
Compound 3: middle estimate off by 1.3-fold (0.10 log units), on the low side; low and high end bracket the measured number.
By their numbers in this assay, from the lowest: compounds 2, 3 and 1 (each within the scatter of the next, the first and the last beyond it).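

In this assay, methoxy in place of fluoro on an aromatic carbon, ortho to a large group, gives a 1.8-fold higher number from compound 2 to compound 3 (0.24 log units; within the scatter), so this position tolerates both groups within the precision of the measurement. Replacing 4-cyanophenyl with 2-methoxyphenyl gives a 1.3-fold lower number from compound 1 to compound 3 (0.11 log units; within the scatter), so unlike compound 2, compound 3 cannot be separated from compound 1. No measurement shown here bears on why these numbers fall as they do.

Still open, from the compounds shown here alone, is how an amine or a carboxylic acid at this position would behave. Ethoxy, a longer chain than methoxy, is equally untested among the compounds shown.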